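A few compounds are considered here, and "the series" means these few. Any claim that something is new, unique, unknown or untested is made for them only; others in the source may bear on it.

Measured so far

Compound 1, `Cc1cccc(C(=O)Nc2ccc3c(c2)CC(NS(C)(=O)=O)C3)c1-c1ccc(Cl)cc1`: 100 nM
Compound 2, `Cc1cccc(C(=O)Nc2ccc3c(c2)CC(NS(=O)(=O)c2cccs2)C3)c1-c1ccc(Cl)cc1`: 120 nM
Compound 3, `Cc1cccc(C(=O)Nc2ccc3c(c2)CC(CNS(C)(=O)=O)C3)c1-c1ccc(C(F)(F)F)cc1`: 150 nM

Notes. Compounds 1 and 2 share one core; compound 3 carries another, and the difference between the two cores is not broken down here. In an assay on isolated protein for inhibition of microsomal triglyceride transfer protein large subunit (Homo sapiens) (a higher number here means a weaker inhibitor, a lower number a stronger inhibitor), compound 1 gives 100 nM, and compound 2, which differs from it by thiophen-2-yl in place of methyl on a sulfonyl sulfur, gives 120 nM. Going by the values given here, that step, a 1.2-fold higher number from compound 1 to compound 2 (0.08 log units; within the scatter), is the only measured instance of this change in the set, and it leaves the two values indistinguishable within the usual scatter.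

Compound 3 gives 150 nM in this assay. Its values against compound 1 and compound 2 all fall within the scatter, so no order among the three is claimed.

Compound 4, `Cc1cccc(C(=O)Nc2ccc3c(c2)CC(CNS(=O)(=O)c2cccs2)C3)c1-c1ccc(C(F)(F)F)cc1`, is not yet measured. It differs from compound 3 by thiophen-2-yl in place of methyl on a sulfonyl sulfur, and this is the same change as that from compound 1 to compound 2, made at the same place, so the two can be compared directly. The expectation for compound 4 therefore rests on compound 3 with 150 nM and on the flat step a 1.2-fold higher number from compound 1 to compound 2 (0.08 log units; within the scatter): the step from compound 3 to compound 4 in this assay is expected to be about a 1.1-fold higher number from compound 3 to compound 4 (0.05 log units; within the scatter), within the scatter. Compound 4 is estimated at 170 nM, with a range from 90 nM to 330 nM. Whether the second core carries this change as quietly as the first is exactly what the pending number will show.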

Compound 4, half-maximal inhibitory concentration: 14 nM
Estimate against measurement, compound 4: 12-fold (1.08 log units) above; measured number outside the range, below it.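

In this assay, thiophen-2-yl in place of methyl on the sulfonyl sulfur gives an 11-fold lower number from compound 3 to compound 4 (1.03 log units; beyond the scatter), a large gain in inhibition on the core of compound 3, whereas the same change on the core of compound 1 stays within the scatter. The change therefore does not carry over from one core to the other with a single size: the same change on two cores in this assay, a 1.2-fold higher number (0.08 log units; within the scatter) from compound 1 to compound 2 and an 11-fold lower number (1.03 log units; beyond the scatter) from compound 3 to compound 4, 13-fold (1.11 log units) apart, beyond the scatter of two such steps. This shows that, in these two pairs, the size of the step depends on the core that carries it, but it does not show which feature of the cores is responsible, and two pairs set no rule for any further core.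

The compounds shown leave open whether the larger step goes with the methylene link in (methanesulfonamido)methyl or with trifluoromethyl in the place of chlorine, since compounds 1 and 3 differ in both and neither is seen alone. Also open, going by these compounds, is how other groups on the sulfonyl sulfur, such as phenyl, furan-2-yl or a longer alkyl chain, would behave on either core.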